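From acetoxy to hydroxymethyl on a sulfonyl chain

The source may report more compounds than this note shows. Statements on the series, on what has been measured and on what is new or still open speak of the compounds shown alone.

Among the compounds with values here, in a physicochemical assay for acid dissociation, compound 2 `CC(=O)OCCCS(=O)(=O)c1ccc(S(N)(=O)=O)s1` gives 8.05, the lowest of the three numbers measured so far. Its nearest neighbour is compound 1 `CC(=O)OCCS(=O)(=O)c1ccc(S(N)(=O)=O)s1` at 8.65, and the furthest is compound 3 `NS(=O)(=O)c1ccc(SCCCCO)s1` at 9.5.

The next compound to be read is compound 4 `NS(=O)(=O)c1ccc(S(=O)(=O)CCCCO)s1`, and the change leading to it is this: hydroxymethyl in place of acetoxy on a saturated chain carbon, three bonds along the chain from a sulfonyl sulfur. In words, hydroxymethyl stands in place of acetoxy on a saturated chain carbon, three bonds along the chain from a sulfonyl sulfur.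

Within the data shown here, only one measured step bears on this change, namely a number 0.60 log units lower from compound 1 to compound 2 (beyond the scatter). There, acetoxymethyl replaces acetoxy two bonds along the chain from a sulfonyl sulfur, and the shift is modest though beyond the scatter. Among the measured compounds shown here, no measured pair shows acetoxy giving way to hydroxymethyl. For the measured compounds named here, compound 3 differs from compound 2 in more than one place and offers no clean step.

With so little to go on, a step in this assay no larger than the modest a number 0.60 log units lower from compound 1 to compound 2 (beyond the scatter) is expected, with only a slight lean upward. The estimated step, a number 0.15 log units higher from compound 2 to compound 4 (within the scatter), is expected to stay within the scatter. Compound 4 is estimated at 8.2, with an expected range from 7.8 to 8.7.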

Compound 4, acid dissociation constant: 8.67
For compound 4 the middle estimate is 0.47 log units below the measured one, within the range that was stated.
By their numbers in this assay, from the lowest: compound 2; then compounds 1 and 4 (each within the scatter of the next); then compound 3.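

In this assay the replacement of acetoxy by hydroxymethyl on a saturated chain carbon, three bonds along the chain from a sulfonyl sulfur, gives a number 0.62 log units higher from compound 2 to compound 4 (beyond the scatter) and so shows that this position also responds to a change of the group itself. Within the data shown here, earlier, the only step along this chain was a number 0.60 log units lower from compound 1 to compound 2 (beyond the scatter) for acetoxymethyl in place of acetoxy. Read with 2-hydroxyethyl in place of acetoxy, two bonds along the chain from a sulfonyl sulfur, the new compound gives a number 0.02 log units higher from compound 1 to compound 4 (within the scatter) and shows that these two different side chains leave the number within the scatter of each other, while no measurement shown speaks to what lies behind any of these steps.

From the compounds shown here alone, whether other groups at this place, such as a carboxylic acid or an amine, would move the number as far remains open. Going by these compounds, it is also open whether hydroxymethyl on a longer chain would stay within the scatter of compound 4 in this assay or move away from it.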